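Moving one fluorine on the benzyl group: expected cytotoxicity

The source may report more compounds than this note shows. Statements on the series, on what has been measured and on what is new or still open speak of the compounds shown alone.

Measured so far:
Compound 1, `CCOC(=O)/C(O)=C/C(=O)c1cn(Cc2cc(F)cc(F)c2)c2cccc(OC)c12`, gives 34700 nM in an ADME assay on MT4 cells (Homo sapiens) for cytotoxicity, read by MTT assay; on this read-out higher numbers stand for lower toxicity in this test and lower numbers for higher toxicity in this test.
Compound 2, `CCOC(=O)/C(O)=C/C(=O)c1cn(Cc2c(F)cccc2F)c2cccc(OC)c12`, gives 63400 nM in this assay.
Compound 3, `CCOC(=O)/C(O)=C/C(=O)c1cn(Cc2ccc(F)c(F)c2F)c2cccc(OC)c12`, gives 42700 nM in this assay.

Among these three numbers compound 3 stands second highest; its nearest neighbour is compound 1 and its furthest is compound 2, and neither gap exceeds the scatter. All three compounds share the same core and differ only in the fluorine pattern of the phenyl group on the saturated chain carbon bound to the aromatic nitrogen.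

Compound 4, `CCOC(=O)/C(O)=C/C(=O)c1cn(Cc2c(F)ccc(F)c2F)c2cccc(OC)c12`, is built from compound 3 by the same kind of change: 2,3,6-trifluorophenyl in place of 2,3,4-trifluorophenyl on a saturated chain carbon bound to an aromatic nitrogen.

The steps already measured are all of this type. They read a 1.8-fold higher number from compound 1 to compound 2 (0.26 log units; within the scatter), a 1.2-fold higher number from compound 1 to compound 3 (0.09 log units; within the scatter) and a 1.5-fold lower number from compound 2 to compound 3 (0.17 log units; within the scatter). None of them moves the number beyond the scatter, so rearranging fluorines on this phenyl ring has so far left cytotoxicity in this assay essentially unchanged.

Compound 4 is therefore expected to sit close to compound 3, with an estimated step of a 1.1-fold higher number from compound 3 to compound 4 (0.02 log units; within the scatter). The estimate for compound 4 is 45000 nM, within a range from 20000 nM to 100000 nM.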

Compound 4, half-maximal cytotoxic concentration: 40500 nM
For compound 4 the middle estimate is 1.1-fold (0.05 log units) above the measured one, within the range that was stated.
By their numbers in this assay, from the lowest: compounds 1, 4, 3 and 2 (each within the scatter of the next).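

The swap of 2,3,4-trifluorophenyl for 2,3,6-trifluorophenyl on the saturated chain carbon bound to the aromatic nitrogen gives, in this assay, a 1.1-fold lower number from compound 3 to compound 4 (0.02 log units; within the scatter). The result also adds a different kind of comparison: fluoro in place of hydrogen on an aromatic carbon gives a 1.6-fold lower number from compound 2 to compound 4 (0.19 log units; within the scatter), and the change from the 3,5-difluorophenyl group to the new ring gives a 1.2-fold higher number from compound 1 to compound 4 (0.07 log units; within the scatter), so across these four compounds neither the pattern nor the number of fluorines on this ring separates any pair beyond the scatter. Nothing available here explains why these compounds cannot be told apart in this test.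

From the compounds shown here alone, all four compounds carry only fluorine on this ring, so it remains open whether a larger substituent such as chlorine or methoxy, an amine on the ring, or a longer chain between the ring and the aromatic nitrogen would give a number outside the scatter. The ethyl ester is also common to all four, which leaves open how a carboxylic acid in its place would read in this test.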